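The source may hold more compounds than are shown below. What is called first, only, known or untested is meant among the compounds shown, and "the series" means these compounds.

Measured compounds in an ADME assay (liver) for metabolic stability, with Liver microsome (Homo sapiens) as the target, read by LC-MS, using microsomes, tested at 1 uM; on this read-out lower numbers stand for a shorter-lived compound and higher numbers for a longer-lived compound:

Compound 1 `C/C(=N/c1ccnc2cc(Cl)ccc12)NCCCCN1CCCCC1`; in this assay compound 1 gives > 1 h, which is a limit of the assay and not a number.
Compound 2 `C/C(=N/c1ccnc2cc(Cl)ccc12)NC1CCN(Cc2ccccc2)CC1`; in this assay compound 2 gives > 1 h, again a limit of the assay.
Compound 3 `CC(C)/C(=N/c1ccnc2cc(Cl)ccc12)NCCCCN1CCCCC1`; in this assay compound 3 gives 0.483 h.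

The difference between the cores of compound 1 and compound 2 is not broken down here. Compound 3 differs from compound 1 by one change, (isopropyl in place of methyl on a carbon with a double bond to nitrogen), and this change made an at least 2.0-fold lower number from compound 1 to compound 3 (0.31 log units; beyond the scatter). The same change, (isopropyl in place of methyl on a carbon with a double bond to nitrogen), leads from compound 2 to the unmeasured compound 4 `CC(C)/C(=N/c1ccnc2cc(Cl)ccc12)NC1CCN(Cc2ccccc2)CC1`. Among the compounds with values here, two of the three values sit at the limit (the limit of > 1 h in this assay, at which 2 of the 3 values shown sit), so the starting point for compound 2 is not a number, and the step from compound 2 to compound 4 can only be set beside the one from compound 1 to compound 3. On that basis a step of similar size is expected, an at least 1.4-fold lower number from compound 2 to compound 4 (0.15 log units; that floor lies within the scatter), with the value of compound 4 in this assay estimated at 0.7 h, ranging from 0.35 h to 1.5 h.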

Compound 4, half-life: 0.417 h
Beside the measured number, compound 4's estimate is 1.7-fold (0.22 log units) above it, and the stated range covers the measured number.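

In this assay, isopropyl in place of methyl on a carbon with a double bond to nitrogen gave an at least 2.3-fold lower number from compound 2 to compound 4 (0.37 log units; beyond the scatter), the same direction as on the core of compound 1: the same change on two cores in this assay, an at least 2.0-fold lower number (0.31 log units; beyond the scatter) from compound 1 to compound 3 and an at least 2.3-fold lower number (0.37 log units; beyond the scatter) from compound 2 to compound 4; the limit leaves it open whether they differ. Both steps are floors, and the starting points on the two cores are limits of the assay and not numbers: the limit of > 1 h in this assay, at which 2 of the 4 values shown sit. Going by these compounds, the direction of the change carries across these two cores, but the true size of each step remains unknown, and the data cannot show that the change has an equal effect on both cores.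

The compounds shown leave open how other groups on that same carbon, such as ethyl or cyclopropyl, would read in this assay, and whether any of them would stay closer to the methyl compounds than isopropyl does. Also open, on these data alone, is whether the lower number seen with isopropyl holds on any core beyond these two.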